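The source may report more compounds than this note shows. Statements on the series, on what has been measured and on what is new or still open speak of the compounds shown alone.

Measured in a functional assay on HOS cells (Homo sapiens) for antiproliferative activity, with a stated time of 72 h; on this read-out lower numbers stand for stronger inhibition and higher numbers for weaker inhibition:
compound 1, `OC[C@H]1O[C@@H](n2cnc3c(NCc4ccccc4F)ncnc32)[C@H](O)[C@@H]1O`, gives > 166000 nM, a limit of the assay and not a number.
compound 2, `OC[C@H]1O[C@@H](n2cnc3c(NCc4ccccc4Cl)ncnc32)[C@H](O)[C@@H]1O`, gives > 166000 nM, likewise a limit.
compound 3, `OC[C@H]1O[C@@H](n2cnc3c(NCc4ccccc4Br)ncnc32)[C@H](O)[C@@H]1O`, gives > 166000 nM, again only a limit.

Compound 1 therefore stands nowhere definite on the numbers shown: its value is a limit, and the two other values shown are limits as well, all sitting at the limit of > 166000 nM in this assay, at which 3 of the 3 values shown sit. The three steps that connect them, a step that the two limits leave unreadable from compound 1 to compound 2, a step that the two limits leave unreadable from compound 1 to compound 3 and a step that the two limits leave unreadable from compound 2 to compound 3, cannot be read for size or direction, since both ends of each step are limits.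

Compound 4, `COc1cccc(CNc2ncnc3c2ncn3[C@@H]2O[C@H](CO)[C@@H](O)[C@H]2O)c1OC`, differs from compound 1 by 2,3-dimethoxyphenyl in place of 2-fluorophenyl on a saturated chain carbon bound to a nitrogen on an aromatic ring. Within the data shown here, none of the measured steps bears on this change in a readable way; the halogen exchanges among compounds 1, 2 and 3 produced no number to compare against. With every measured compound at the limit, the expectation for compound 4 rests on the shared core alone, and the step is expected as a number no higher from compound 1 to compound 4 (the limit leaves the size open), most likely again ending at a limit rather than a number. Compound 4 is thus estimated at 166000 nM, in a range from 30000 nM to 500000 nM.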

Compound 4, half-maximal inhibitory concentration: > 166000 nM
Compound 4: only a limit was reported (the forecaster's own chance of this, stated with the estimate: 75%); the middle value lies on the limit itself.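

In this assay compound 4 gives > 166000 nM, a limit of the assay and not a number. No step from compound 1, compound 2 or compound 3 to compound 4 can be read, because every value sits at the same limit: the limit of > 166000 nM in this assay, at which 4 of the 4 values shown sit.

The compounds shown leave open whether 2,3-dimethoxyphenyl or any of the halogen exchanges changes the read-out at all.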